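The compounds below may be only part of what the source reports. "The series", "measured", "known", "first", "only" and "open" are said of these compounds alone.

Compounds measured so far:
compound 1, `COc1ccc(-c2cc3cc(-c4ccccc4)cc(C(C)=O)c3[nH]2)cc1`, 78.1%;
compound 2, `COc1ccc(-c2cc3cc(-c4ccc(F)cc4)cc(C(C)=O)c3[nH]2)cc1`, 96.4%;
compound 3, `CC(=O)c1cc(/C=C/c2ccccc2)cc2cc(-c3ccccc3)[nH]c12`, 93.4%.

The three compounds were tested in a functional assay on MCF7 cells (Homo sapiens) for cytotoxicity, read by MTT assay, with a stated time of 2 days, tested at 1 uM; on this read-out lower numbers stand for a stronger effect and higher numbers for a weaker effect at the one concentration tested. Compound 1 gives 78.1% and compound 2 gives 96.4%; the change between them is fluoro in place of hydrogen on an aromatic carbon and it made a step of a number 18.3 percentage points higher from compound 1 to compound 2 (beyond the scatter). Compound 3 gives 93.4%, which lies within the scatter of the number for compound 2 and beyond the scatter of the number for compound 1. The difference between the core of compound 1 and the core of compound 3 is not broken down here.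

Compound 4, `CC(=O)c1cc(/C=C/c2ccc(F)cc2)cc2cc(-c3ccccc3)[nH]c12`, has not yet been measured in this assay. It differs from compound 3 by fluoro in place of hydrogen on an aromatic carbon, the same change as that from compound 1 to compound 2, made at a place described in the same words. Since the number for compound 3 already stands close to the top of the scale, the expected step is a number 4.6 percentage points higher from compound 3 to compound 4 (within the scatter), smaller than the earlier step because compound 3 gives 93.4% and leaves limited room above it, while the direction follows a number 18.3 percentage points higher from compound 1 to compound 2 (beyond the scatter). For compound 4 the expected number in this assay is 98%, estimated to fall between 88% and 106%.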

Compound 4, a percentage reported as activity, at one concentration (the size of the read-out at that concentration, not a potency): 72.2%
Estimate against measurement, compound 4: 25.8 percentage points above; the measured number lies below the stated range.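

In this assay, fluoro in place of hydrogen on an aromatic carbon gave a number 21.2 percentage points lower from compound 3 to compound 4 (beyond the scatter), which on this read-out is a stronger effect at the one concentration tested. The same change gave a weaker effect on the core of compound 1, so its direction did not carry over from one core to the other: the same change on two cores in this assay, a number 18.3 percentage points higher (beyond the scatter) from compound 1 to compound 2 and a number 21.2 percentage points lower (beyond the scatter) from compound 3 to compound 4, 39.5 percentage points apart, beyond the scatter of two such steps

This shows that, among these compounds, the outcome of adding fluoro on one core cannot be taken as a guide to its outcome on the other, although the change is described in the same words in both pairs. It does not show why the two steps part, since the fluoro enters a phenyl group in one pair and a 2-phenylethenyl group in the other, and two pairs cannot say how the change would behave on any further core.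

As far as these compounds go, what a chloro group, an amine or a carboxylic acid at that same place would do on either core remains open. A read-out at a single concentration also leaves open how these steps would look as potencies.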